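The source may hold more compounds than are shown below. What is called first, only, known or untested is meant among the compounds shown, and "the series" means these compounds.

Of the compounds shown here, two have been tested in an ADME assay on Huh7.5.1 cells (Homo sapiens) for cytotoxicity, read by ATP content, with a stated time of 48 h; on this read-out lower numbers stand for higher toxicity in this test and higher numbers for lower toxicity in this test. Compound 1 `Cc1ccccc1-c1nc(CN2CCC(C(=O)NCCCN3CCC(C(C)C)CC3)CC2)c(C)o1` gives 4280 nM in this assay. Compound 2 `Cc1oc(-c2ccc(F)cc2)nc1CN1CCC(C(=O)NCCCN2C[C@H](C)C[C@H](C)C2)CC1` gives 12800 nM in this assay, the highest of the two numbers and therefore the less toxic of the pair, with compound 1 standing at a lower number beyond the usual scatter.

The next compound, compound 3 `Cc1ccc(-c2nc(CN3CCC(C(=O)NCCCN4C[C@H](C)C[C@H](C)C4)CC3)c(C)o2)cc1`, differs from compound 2 in one place: methyl in place of fluoro on an aromatic carbon. The change sits on an aromatic carbon of a six-membered aromatic ring of carbon only, para to a large group. Among the measured compounds shown here, no measured pair in this set shows a fluoro-to-methyl swap, so nothing in the numbers fixes its size. A small change in toxicity is expected, toward a somewhat lower number, shown as a 1.4-fold lower number from compound 2 to compound 3 (0.15 log units; within the scatter) in this assay, though a step within the scatter would not be surprising. For compound 3 a value of 9000 nM is estimated in this assay, within a range from 4000 nM to 20000 nM.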

Compound 3, half-maximal cytotoxic concentration: 4330 nM
Estimate against measurement, compound 3: 2.1-fold (0.32 log units) above; measured number inside the range.
By their numbers in this assay, from the lowest: compounds 1 and 3 (each within the scatter of the next); then compound 2.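

Among the compounds shown here, this is the first pair in this assay that differs in only one place, so it gives the first direct reading of this position. Replacing 4-fluorophenyl with 4-methylphenyl gives a 3.0-fold lower number from compound 2 to compound 3 (0.47 log units; beyond the scatter) and so points toward higher toxicity in this test. Exchanging a single heavy atom on an aromatic carbon, para to a large group, is therefore enough to move the result past the usual scatter, although nothing available gives a measured reason for this step.

The compounds shown leave open how hydrogen, chloro or methoxy would read at this place, and so whether the step reflects losing fluoro or gaining methyl. They also leave open whether the same swap gives a similar step when a different amine ends the chain.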